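The source may hold more compounds than are shown below. What is called first, only, known or untested is meant among the compounds shown, and "the series" means these compounds.

The series shares one core, seen in compound 1 (`CCc1ccc(NC2=CC(=O)c3c(nc4n3[C@H]3OC[C@@H](O)[C@H]3OC4)C2=O)cc1`), compound 2 (`O=C1C=C(Nc2ccccc2F)C(=O)c2c1nc1n2[C@H]2OC[C@@H](O)[C@H]2OC1`) and compound 3 (`COc1ccc(NC2=CC(=O)c3c(nc4n3[C@H]3OC[C@@H](O)[C@H]3OC4)C2=O)cc1`). In a functional assay on ECa-109 cells for inhibition, with ECa-109 cell line (Homo sapiens) as the target, read by sulforhodamine B assay (on this read-out lower numbers stand for stronger inhibition and higher numbers for weaker inhibition), compound 1 gives > 4000 nM, which is a limit of the assay and not a number. In this assay compound 2 gives 2760 nM. Compound 3 carries methoxy in place of ethyl on an aromatic carbon, para to a large group: methoxy in place of ethyl on an aromatic carbon. Among the compounds with values here, no measured step covers this change, so no shift in this assay beyond the scatter is expected, and the direction stays open. The expected step is an at least 1.1-fold lower number from compound 1 to compound 3 (0.05 log units; that floor lies within the scatter). The estimated value for compound 3 is 3500 nM, with an expected range of 1500 nM to 8000 nM.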

Compound 3, half-maximal inhibitory concentration: 3410 nM
The estimate for compound 3 lay 1.0-fold (0.01 log units) above the measured number, within the range that was stated.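

In this assay, methoxy in place of ethyl on this aromatic carbon gives an at least 1.1-fold lower number from compound 1 to compound 3 (0.06 log units; that floor lies within the scatter). Within the data shown here, compound 3 supplies the first measured number for a group at this position, 3410 nM. Compound 1 is held only by a limit of the assay, so the step has a floor and no true size: the limit of > 4000 nM in this assay, at which 1 of the 3 values shown sits.

Open, from the compounds shown here alone, is what a group of another kind would do on the same aromatic carbon, such as an amine, a carboxylic acid or a longer chain like butyl. Going by these compounds, the direction of this change also stays open until the ethyl compound has a number.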